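A few compounds are considered here, and "the series" means these few. Any claim that something is new, unique, unknown or untested is made for them only; others in the source may bear on it.

The measured compounds:
compound 1, `CCc1ccccc1-c1nc(N)nc(N)n1`: 1.65
compound 2, `Cc1ccc(-c2nc(N)nc(N)n2)cc1`: 1.92
compound 3, `Cc1c(N(C)C)c(=O)n(C)c(=O)n1-c1ccc(Cl)cc1`: 2.32

In a physicochemical assay for lipophilicity (a higher number here means a more lipophilic compound, a lower number a more polar compound), compound 1 has the lowest of the three numbers. Compound 2 lies nearest to it, and the gap between the two falls within the scatter of this assay. Compound 3 lies furthest away, its number higher by a gap beyond the scatter.

The unmeasured compound 4, `Nc1nc(N)nc(-c2ccccc2Br)n1`, is derived from compound 1 by a single change: bromo in place of ethyl on an aromatic carbon. The ethyl group leaves and a bromo group takes its place on an aromatic carbon of a six-membered aromatic ring of carbon only.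

Within the data shown here, with no comparable step among the measured compounds, only a small expected step, downward at most, is assumed: a number 0.10 log units lower from compound 1 to compound 4 (within the scatter), probably not beyond the scatter. Compound 4 is therefore expected to give about 1.55 in this assay, within a range from 1.2 to 1.9.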

Compound 4, partition coefficient: 1.26
Compound 4: middle estimate off by 0.29 log units, on the high side; the range from low to high includes it.
By their numbers in this assay, from the lowest: compound 4; then compounds 1 and 2 (each within the scatter of the next); then compound 3.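

In this assay, among these compounds, bromo in place of ethyl on an aromatic carbon, ortho to a group of 8 heavy atoms, gives a number 0.39 log units lower from compound 1 to compound 4 (beyond the scatter), the first step that can be read at this position. The position therefore responds to a single change, and compound 4 now holds the lowest number of the four. Among the compounds shown here, nothing measured so far bears on the reason for this step.

The compounds shown leave open how chloro, methoxy, an amine or a carboxylic acid on this same aromatic carbon would read. They also leave open whether the step from ethyl to bromo would recur on another core.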